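Replacing chloro with isopropyl in the series

The source may hold more compounds than are shown below. What is called first, only, known or untested is meant among the compounds shown, and "the series" means these compounds.

In an ADME assay on the whole organism (Rattus norvegicus) for pharmacokinetics, read by HPLC, at a dose of 3 mg/kg by the oral route (on this read-out higher numbers stand for higher exposure at the dose given and lower numbers for lower exposure), compound 3 (`N#Cc1cc(C(=O)N2CS(=O)(=O)c3ccccc32)cc(Cl)c1O`) gives 3870 nM, within the scatter of compound 1 (`N#Cc1cc(C(=O)N2CCc3ccccc32)cc(C2CC2)c1O`) at 4470 nM, while compound 2 (`N#Cc1cc(C(=O)N2CS(=O)(=O)c3ccccc32)cc(C2CC2)c1O`) gives 10800 nM. Compound 4 (`CC(C)c1cc(C(=O)N2CS(=O)(=O)c3ccccc32)cc(C#N)c1O`), not yet measured, carries isopropyl in place of chloro on an aromatic carbon. Among the measured compounds shown here, the one measured step at this carbon, a 2.8-fold lower number from compound 2 to compound 3 (0.45 log units; beyond the scatter), put chloro in place of cyclopropyl and was modest. With the exchange running the other way and isopropyl itself untested, a higher number of similar or smaller size is expected in this assay. The expected step is a 2.1-fold higher number from compound 3 to compound 4 (0.32 log units; beyond the scatter). For compound 4 the estimate is 8000 nM, with an expected range of 3800 nM to 16000 nM.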

Compound 4, maximal plasma concentration: 12500 nM
Compound 4: middle estimate off by 1.6-fold (0.19 log units), on the low side, within the range that was stated.
By their numbers in this assay, from the lowest: compounds 3 and 1 (each within the scatter of the next); then compounds 2 and 4 (each within the scatter of the next).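

On the aromatic carbon ortho to a hydroxy group, isopropyl in place of chloro gives a 3.2-fold higher number from compound 3 to compound 4 (0.51 log units; beyond the scatter) in this assay. Isopropyl in place of cyclopropyl gives a 1.2-fold higher number from compound 2 to compound 4 (0.06 log units; within the scatter), so the two carbon groups stand level at this position, and of the three groups compared here only chloro, in compound 3, gives the lower number. Nothing measured here accounts for these steps.

Open, from the compounds shown here alone, is how an amine or a methoxy group would read at this carbon. Also open, going by these compounds, is whether isopropyl gives the same step on the core of compound 1.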